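Benzimidazole-pyrazolone series: 2-chlorophenyl to 3,4-dichlorophenyl

The source may report more compounds than this note shows. Statements on the series, on what has been measured and on what is new or still open speak of the compounds shown alone.

In an assay on isolated protein for inhibition of alpha-ketoglutarate-dependent dioxygenase alkB homolog 3 (Homo sapiens), read by polymerase chain reaction, with a stated time of 1 h (a lower number here means a stronger inhibitor, a higher number a weaker inhibitor), compound 1 `Cc1[nH]n(-c2nc3ccccc3[nH]2)c(=O)c1Cc1ccc(C(F)(F)F)cc1` gives 550 nM, compound 2 `Cc1ccc2[nH]c(-n3[nH]c(C)c(C)c3=O)nc2c1` gives 2600 nM and compound 3 `Cc1ccc2[nH]c(-n3[nH]c(C)c(Cc4ccccc4Cl)c3=O)nc2c1` gives 910 nM. Compound 3 stands second of the three numbers: its gap to compound 1 is within the scatter, while a 2.9-fold lower number from compound 2 to compound 3 (0.46 log units; beyond the scatter) is beyond it. Compound 4 `Cc1ccc2[nH]c(-n3[nH]c(C)c(Cc4ccc(Cl)c(Cl)c4)c3=O)nc2c1` differs from compound 3 by 3,4-dichlorophenyl in place of 2-chlorophenyl on a saturated chain carbon bound to an aromatic carbon. For the measured compounds named here, no measured step changes one aryl group for another; the only step that bears on the benzylic aryl is a 2.9-fold lower number from compound 2 to compound 3 (0.46 log units; beyond the scatter), which shows that an aryl group at this position helps. Nothing shows whether the substitution pattern matters. The expectation for compound 4 in this assay is a step of a 1.4-fold lower number from compound 3 to compound 4 (0.15 log units; within the scatter), within the scatter, giving an estimated 650 nM with a range from 250 nM to 1700 nM.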

Compound 4, half-maximal inhibitory concentration: 720 nM
Estimate against measurement, compound 4: 1.1-fold (0.04 log units) below, and the stated range covers the measured number.
By their numbers in this assay, from the lowest: compounds 1, 4 and 3 (each within the scatter of the next); then compound 2.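

In this assay, 3,4-dichlorophenyl in place of 2-chlorophenyl gives a 1.3-fold lower number from compound 3 to compound 4 (0.10 log units; within the scatter) on the saturated chain carbon bound to an aromatic carbon, so the two aryl groups cannot be told apart at this position. Against hydrogen at the same place, 3,4-dichlorophenyl gives a 3.6-fold lower number from compound 2 to compound 4 (0.56 log units; beyond the scatter) as a second case alongside compound 3, so the benefit of an aryl group there does not rest on one substitution pattern. Nothing available explains these numbers.

Still open, going by these compounds, is whether an amine, a carboxylic acid or a longer chain carrying the 3,4-dichlorophenyl would keep this level at the same position.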